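Compound 4: An Anilinoethyl Amide Near the Assay Limit

This account rests on a few compounds, and the source may have more. Where it says the series, first, only, none or still open, it means among the compounds named here.

In a functional assay on A549 cells (Homo sapiens) for antiproliferative activity, read by MTT assay, with a stated time of 48 h (a lower number here means a stronger inhibitor, a higher number a weaker inhibitor), compound 1 `Cc1c(C(=O)OCCCN(C)C)oc2ccc(N(Cc3ccc(Br)cc3)S(=O)(=O)c3ccc(Br)cc3)cc12` gives > 40000 nM as a limit of the assay and not a number. Compound 3 `Cc1ccc(NC(=O)c2oc3ccc(N(Cc4ccc(Br)cc4)S(=O)(=O)c4ccc(Br)cc4)cc3c2C)nc1` likewise gives > 40000 nM as a limit only. Among the measured compounds shown here, compound 2 `Cc1c(C(=O)NCC(O)CO)oc2ccc(N(Cc3ccc(Br)cc3)S(=O)(=O)c3ccc(Br)cc3)cc12` gives 30500 nM as the one true number in the set. The measured compounds thus sit largely at the limit of > 40000 nM in this assay, at which 2 of the 3 values shown sit, with little readable range.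

The step to compound 4 `Cc1c(C(=O)NCCNc2ccccc2)oc2ccc(N(Cc3ccc(Br)cc3)S(=O)(=O)c3ccc(Br)cc3)cc12` puts 2-anilinoethyl in place of 5-methylpyridin-2-yl on an amide-type nitrogen, as 2-anilinoethyl in place of 5-methylpyridin-2-yl on an amide-type nitrogen sets out in full. The earlier changes on the carbonyl carbon offer an at least 1.3-fold lower number from compound 1 to compound 2 (0.11 log units; that floor lies within the scatter) and also a step that the two limits leave unreadable from compound 1 to compound 3 as their outcome. For the measured compounds named here, no step beyond the scatter is expected in this assay since an at least 1.3-fold higher number from compound 2 to compound 3 (0.11 log units; that floor lies within the scatter) is the closest precedent on the same nitrogen. The expected step is an at least 1.2-fold lower number from compound 3 to compound 4 (0.09 log units; that floor lies within the scatter) and it may not be readable at all. Compound 4 is estimated at 32000 nM with an expected range from 14000 nM to 60000 nM and may well return only a limit.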

Compound 4, half-maximal inhibitory concentration: > 40000 nM
Compound 4: only a limit was reported (the forecaster's own chance of this, stated with the estimate: 50%); middle value at least 1.2-fold (0.09 log units) away from the limit.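

In this assay compound 4 gives > 40000 nM, which is a limit of the assay and not a number. Among the compounds shown here, the steps to it from compound 1 and compound 3 cannot be read, and the one readable step, an at least 1.3-fold higher number from compound 2 to compound 4 (0.11 log units; that floor lies within the scatter), stays within the usual scatter. On this amide-type nitrogen, neither 5-methylpyridin-2-yl nor 2-anilinoethyl, with its carbon-only aromatic ring and its hydrogen-bond donor, brings a true number, and both end at the same place: the limit of > 40000 nM in this assay, at which 3 of the 4 values shown sit.

On these data alone, how far beyond the limit compound 1, compound 3 and compound 4 lie remains open. Also open, as far as these compounds go, is whether a carboxylic acid, a morpholine or a longer chain on this nitrogen would give a number that could be read.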